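From a fluorobenzyl ether toward a plain butoxy chain

This account rests on a few compounds, and the source may have more. Where it says the series, first, only, none or still open, it means among the compounds named here.

Measured so far:
compound 1 `CCc1nncn1-c1ccc(OCc2cccc(F)c2)cc1`, 22.8 mg/kg
compound 2 `CCc1nncn1-c1ccc(OCc2c(F)cccc2F)cc1`, 15.8 mg/kg
compound 3 `CCc1nncn1-c1ccc(OCc2c(Cl)cccc2Cl)cc1`, 15.8 mg/kg

In a functional assay on the whole organism (strain C57B/6) with Mus musculus as the target, in the maximal electroshock model (on this read-out higher numbers stand for an effect only at larger amounts of compound and lower numbers for an effect already at smaller amounts), compound 1 gives 22.8 mg/kg, the highest of the three numbers, yet its distance to both compound 2 and compound 3 lies within the scatter, so no order among the three can be claimed. Compound 4 `CCCCOc1ccc(-n2cnnc2CC)cc1` has not yet been measured. It differs from compound 1 in one place: propyl in place of 3-fluorophenyl on a saturated chain carbon bound to an oxygen on an aromatic ring. Within the data shown here, no step of this kind between measured compounds is known, so the expectation rests on the change alone. The step of a 1.8-fold higher number from compound 1 to compound 4 (0.24 log units; within the scatter) is expected to go beyond the scatter, toward a larger dose. For compound 4 the expected value in this assay is 40 mg/kg, with a range from 15 mg/kg to 120 mg/kg.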

Compound 4, dose for half-maximal effect: > 100 mg/kg
Compound 4 ended at the assay's limit (the forecaster's own chance of this, stated with the estimate: 20%); middle value at least 2.5-fold (0.39 log units) from the limit.
By their numbers in this assay, from the lowest: compounds 2, 3 and 1 (each within the scatter of the next). At a limit, above all of these: compound 4.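

Putting propyl in place of 3-fluorophenyl gives, in this assay, an at least 4.3-fold higher number from compound 1 to compound 4 (0.64 log units; beyond the scatter), the first difference among these compounds that lies beyond the scatter. The group on this saturated chain carbon therefore matters for the dose needed, which compounds 1 to 3, all within the scatter of one another, could not show. Compound 4 reads > 100 mg/kg, which is a limit and not a number.

On these data alone, whether the loss follows from losing the aromatic ring or from the chain itself stays open. A cyclohexyl group or a longer chain such as hexyl here could help separate the two.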